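This account rests on a few compounds, and the source may have more. Where it says the series, first, only, none or still open, it means among the compounds named here.

Measured so far in a functional assay on HepG2 cells (Homo sapiens) for cytotoxicity, read by MTT assay; on this read-out lower numbers stand for stronger inhibition and higher numbers for weaker inhibition: compound 1 `C#CCOc1cc(/C=C/C(=O)c2ccc(OC)c3c2OC(C)(C)C=C3)ccc1OC` gives only a limit of the assay, > 10000 nM. Compound 2 `CCC(=O)Oc1cc(/C=C/C(=O)c2ccc(OC)c3c2OC(C)(C)C=C3)ccc1OC` gives 90 nM. Compound 3 `C=CC(=O)Oc1cc(/C=C/C(=O)c2ccc(OC)c3c2OC(C)(C)C=C3)ccc1OC` gives 160 nM.

Compound 2 holds the lowest of the two numbers given; the nearest is a 1.8-fold higher number from compound 2 to compound 3 (0.25 log units; within the scatter), and compound 1 contributes the limit of > 10000 nM in this assay, at which 1 of the 3 values shown sits, rather than a number. Compound 4 `COc1ccc(/C=C/C(=O)c2ccc(OC)c3c2OC(C)(C)C=C3)cc1CS(C)(=O)=O` differs from compound 2 in one place: (methylsulfonyl)methyl in place of propanoyloxy on an aromatic carbon. Among the measured compounds shown here, two measured steps bear on this position: an at least 110-fold lower number from compound 1 to compound 2 (2.04 log units; beyond the scatter) and an at least 62-fold lower number from compound 1 to compound 3 (1.79 log units; beyond the scatter), both large, show that exchanging the group at this point moves the number strongly, while a 1.8-fold higher number from compound 2 to compound 3 (0.25 log units; within the scatter) shows that two closely related esters sit together. For the measured compounds named here, nothing measured here carries a (methylsulfonyl)methyl group, so the new substituent has no direct counterpart. Since the ester that gave the low numbers leaves compound 4 entirely, its number is expected to rise, a 22-fold higher number from compound 2 to compound 4 (1.35 log units; beyond the scatter). Compound 4 is therefore estimated at 2000 nM, expected to lie between 300 nM and 10000 nM.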

Compound 4, half-maximal inhibitory concentration: 9180 nM
Compound 4: middle estimate off by 4.6-fold (0.66 log units), on the low side, within the range that was stated.
By their numbers in this assay, from the lowest: compounds 2 and 3 (each within the scatter of the next); then compound 4. At a limit, above all of these: compound 1.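

Exchanging propanoyloxy for (methylsulfonyl)methyl keeps the heavy-atom count and the count of hydrogen-bond acceptors, yet it gives a 100-fold higher number from compound 2 to compound 4 (2.01 log units; beyond the scatter), and the change from (vinylcarbonyl)oxy gives a 57-fold higher number from compound 3 to compound 4 (1.76 log units; beyond the scatter), so matching those counts does not preserve the low numbers at this position. Among the compounds shown, only the two esters give low numbers, while the propargyloxy and (methylsulfonyl)methyl groups both leave the number high, and an at least 1.0-fold lower number from compound 1 to compound 4 (0.03 log units; that floor lies within the scatter) sets no order between these two. Compound 1 gives no number, only a limit: the limit of > 10000 nM in this assay, at which 1 of the 4 values shown sits.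

From the compounds shown here alone, whether the low numbers need the ester itself or only a carbonyl at this point stays open. A hydroxy group, an amide or a longer-chain ester on this aromatic carbon would bear on that question, and none is among the compounds shown.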